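Compound 2 to compound 3: a sulfonyl swap

This account rests on a few compounds, and the source may have more. Where it says the series, first, only, none or still open, it means among the compounds named here.

In an ADME assay on L6 cells (Rattus norvegicus) for cytotoxicity (a higher number here means a weaker inhibitor, a lower number a stronger inhibitor), compound 1 `O=[N+]([O-])c1ncn(CCCNS(=O)(=O)Cc2ccccc2)n1` gives > 307000 nM, which is a limit. Compound 2 `Cn1ccnc1S(=O)(=O)NCCCn1cnc([N+](=O)[O-])n1` gives > 317000 nM, also a limit, and so has no number of its own. Compound 3 `O=[N+]([O-])c1ncn(CCCNS(=O)(=O)c2ccc(Cl)s2)n1` replaces one group on the sulfonyl sulfur: 5-chlorothiophen-2-yl in place of 1-methyl-1H-imidazol-2-yl on a sulfonyl sulfur. For the measured compounds named here, the only measured step bearing on this change, a step that the two limits leave unreadable from compound 1 to compound 2, has no readable size, so the expectation remains loose. A modest move towards a lower number is expected, with an at least 1.8-fold lower number from compound 2 to compound 3 (0.27 log units; that floor lies within the scatter) as the estimated step. For compound 3 the estimated value is 170000 nM, within a range of 50000 nM to 300000 nM.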

Compound 3, half-maximal inhibitory concentration: 244000 nM
For compound 3 the middle estimate is 1.4-fold (0.16 log units) below the measured one; low and high end bracket the measured number.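

In this assay, for the compounds shown here, compound 3 gives 244000 nM, the first number that is not a limit, so 5-chlorothiophen-2-yl on a sulfonyl sulfur gives a value that can be read. The two new steps are an at least 1.2-fold lower number from compound 2 to compound 3 (0.11 log units; that floor lies within the scatter) and an at least 1.2-fold lower number from compound 1 to compound 3 (0.09 log units; that floor lies within the scatter); both are only floors, so they set no order among the three compounds. The step between compound 1 and compound 2 cannot be read.

On these data alone, whether any group at this place moves the number beyond the scatter stays open. Also open, as far as these compounds go, is how an amine or a carboxylic acid in place of 5-chlorothiophen-2-yl would read in this assay.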